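A few compounds are considered here, and "the series" means these few. Any claim that something is new, unique, unknown or untested is made for them only; others in the source may bear on it.

Of the compounds shown here, two that share a core have been measured in a functional assay on the whole organism (strain Swiss albino) for inhibition, with Mus musculus as the target, in the writhing test, with stated times of 60 min and 15 min, at a dose of 100 mg/kg by the oral route; on this read-out lower numbers stand for less inhibition and higher numbers for more inhibition at the one dose given (going by the name of the read-out). Compound 1 `COc1cc2c(cc1OC)C(CC(=O)NC(C)C)CC2` carries an isopropylamino group on its carbonyl carbon, and in this assay compound 1 gives 29.3%. Compound 2 `COc1cc2c(cc1OC)C(CC(=O)N1CCCCC1)CC2` carries a piperidin-1-yl group there instead, and in this assay compound 2 gives 44.7%. Within the data shown here, the one step between them, a number 15.4 percentage points higher from compound 1 to compound 2 (beyond the scatter), shows that closing the amine into a six-membered ring raised the read-out. Compound 2 thus stands highest of the two measured numbers, with compound 1 lower by a step beyond the scatter.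

Compound 3 `COc1cc2c(cc1OC)C(CC(=O)N1CCNCC1)CC2` differs from compound 2 in one place: piperazin-1-yl in place of piperidin-1-yl on a carbonyl carbon. The ring size and its attachment to the carbonyl carbon stay the same; only a hetero atom enters the ring. Among the measured compounds shown here, the single step measured so far concerns opening or closing the ring, not a change within it, so it bears only loosely on this change. Compound 3 is therefore expected to stay close to compound 2, with a step of a number 6.7 percentage points lower from compound 2 to compound 3 (within the scatter) that is expected to fall within the scatter. The estimate for compound 3 in this assay is 38%, with a range from 22% to 55%.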

Compound 3, a percentage reported as inhibition, in the whole organism at one dose (the size of the read-out at that dose, not a potency): 68.8%
Compound 3: middle estimate off by 30.8 percentage points, on the low side, outside the stated range (above it).
By their numbers in this assay, from the lowest: compound 1; then compound 2; then compound 3.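

In this assay, a change inside the ring on the carbonyl carbon turns out to matter: piperazin-1-yl keeps the ring size and attachment of piperidin-1-yl, yet gives a number 24.1 percentage points higher from compound 2 to compound 3 (beyond the scatter), so this position responds to more than whether the amine is closed into a ring. Measured against the open isopropylamino group, the same ring gives a number 39.5 percentage points higher from compound 1 to compound 3 (beyond the scatter), the only large step among these compounds. Piperazin-1-yl brings a second hetero atom, along with one hydrogen-bond donor and one hydrogen-bond acceptor by the count used here, where piperidin-1-yl has none, but no measurement available here separates these features or explains the rise.

Still open, from the compounds shown here alone, is whether the second ring nitrogen needs its hydrogen, and a piperazine ring with a methyl group on that nitrogen, or a morpholine ring with oxygen in its place, would help to separate those possibilities. Also open, going by these compounds, is how the three compounds would compare at other doses, as each number here gives the size of the read-out at a single dose rather than a potency.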